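Amino for dimethylamino on a two-ring core

This account rests on a few compounds, and the source may have more. Where it says the series, first, only, none or still open, it means among the compounds named here.

Compounds measured:
compound 1 `CCCCCn1c(N)nc2c(F)cccc21` — "not active" (no number reported)
compound 2 `CCCCCn1c(N)nc2c(Br)cccc21` — "not active" (no number reported)
compound 3 `CCCCCn1c(N)nc2c(N(C)C)cccc21` — 7120 nM

The three measured compounds share one core and differ only in the group on one aromatic carbon. In an assay on HEK293 cells for agonist activity at Toll-like receptor 8 (Homo sapiens), read by reporter gene assay (a higher number here means that more compound is needed for the effect, a lower number that less compound is needed), compound 1 is reported as "not active" (no number reported), a report without a number. Compound 2 is likewise reported in this assay as "not active" (no number reported), again without a number. For the measured compounds named here, compound 3 is the only one of the three with a measured half-maximal effective concentration, giving 7120 nM in this assay, so it stands alone as the sole numerical reference here; no step between measured compounds with numbers can be drawn.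

Compound 4 `CCCCCn1c(N)nc2c(N)cccc21` has not yet been measured. It differs from compound 3 in one place: amino in place of dimethylamino on an aromatic carbon. Going by the values given here, with no measured step of this kind among the compounds here, the size and direction of the change is open; a step within the usual scatter or a modest shift in either direction seems equally plausible. Compound 4 is therefore expected to give about 5000 nM in this assay, within a range from 1500 nM to 20000 nM, which would mean an expected step of a 1.4-fold lower number from compound 3 to compound 4 (0.15 log units; within the scatter).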

Compound 4, half-maximal effective concentration: 6600 nM
Beside the measured number, compound 4's estimate is 1.3-fold (0.12 log units) below it; the measured number falls inside the stated range.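

In this assay, the step of a 1.1-fold lower number from compound 3 to compound 4 (0.03 log units; within the scatter) shows that amino and dimethylamino on this aromatic carbon cannot be told apart, even though amino has fewer heavy atoms and brings a hydrogen-bond donor. Compound 4 is also a second compound with a number at this place, whereas the steps to compound 1 and compound 2, both reported without a number, cannot be read. Nothing measured here gives a reason for this result.

The compounds shown leave open whether methylamino, methoxy or hydroxyl on the same aromatic carbon would also give a number in this assay. They also leave open whether a hexyl chain in place of the pentyl chain would change the number for compound 4.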